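Trimethoxyphenyl regioisomer step: cytotoxicity working notes

This account rests on a few compounds, and the source may have more. Where it says the series, first, only, none or still open, it means among the compounds named here.

Measured so far:
compound 1 `COc1ccc(/C=C/C(=O)c2ccc(OCC(O)CNCCNc3ccnc4cc(Cl)ccc34)cc2)cc1OC` — 10200 nM
compound 2 `COc1cc(/C=C/C(=O)c2ccccc2OCC(=O)NCCNc2ccnc3cc(Cl)ccc23)cc(OC)c1OC` — 3920 nM

In an ADME assay on Vero cells (Chlorocebus sabaeus) for cytotoxicity, read by MTT assay, with a stated time of 72 h (on this read-out higher numbers stand for lower toxicity in this test and lower numbers for higher toxicity in this test), compound 1 gives 10200 nM, and compound 2 gives 3920 nM. Compound 2 stands lowest of the two numbers; the nearest, compound 1, sits higher by a gap beyond the scatter, so on this read-out compound 2 shows the higher toxicity of the pair. Among the measured compounds shown here, no step between compounds that differ in a single place is available, and compound 1 and compound 2 differ in more than one place, so their two values only mark the spread seen so far.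

Compound 3 `COc1cc(OC)c(OC)cc1/C=C/C(=O)c1ccccc1OCC(=O)NCCNc1ccnc2cc(Cl)ccc12` is to be measured in this assay. It differs from compound 2 in one place: 2,4,5-trimethoxyphenyl in place of 3,4,5-trimethoxyphenyl on a double-bonded chain carbon bound to a double-bonded chain carbon. The two have the same atoms joined differently, and nothing measured here bears on this exchange, so the expectation rests on compound 2 alone. The expected step is a 1.1-fold higher number from compound 2 to compound 3 (0.06 log units; within the scatter), that is, none beyond the scatter in either direction. Compound 3 is therefore estimated at 4500 nM, with a range from 1800 nM to 11000 nM.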

Compound 3, half-maximal cytotoxic concentration: 12300 nM
For compound 3 the middle estimate is 2.7-fold (0.44 log units) below the measured one, outside the stated range (above it).
By their numbers in this assay, from the lowest: compound 2; then compounds 1 and 3 (each within the scatter of the next).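

In this assay, among the compounds shown here, 2,4,5-trimethoxyphenyl in place of 3,4,5-trimethoxyphenyl on a double-bonded chain carbon bound to a double-bonded chain carbon gives a 3.1-fold higher number from compound 2 to compound 3 (0.50 log units; beyond the scatter) and is the only single-place comparison so far. The two groups have the same heavy atoms, the same aromatic ring and the same counts of donors and acceptors, so this place responds to how the same atoms are joined, and the change here goes towards lower toxicity in this test, a reading that the different compounds 1 and 2 could not give. Nothing measured alongside this result accounts for the step.

As far as these compounds go, whether other groups at this place, such as a pyridine ring or a phenyl ring carrying a single hydroxyl, would move the number in the same direction remains open. Also open, from the compounds shown here alone, is whether the same exchange would give a step of similar size on the chain and ring arrangement of compound 1, or only on the shared core of compound 2 and compound 3.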